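This account rests on a few compounds, and the source may have more. Where it says the series, first, only, none or still open, it means among the compounds named here.

Working notes on the series.

Compound 1 `Cc1ccc2nc(C(=O)Nc3c(F)cc(-c4cccc(F)c4)cc3F)c(C)c(O)c2c1` and compound 2 `CCc1ccc2nc(C(=O)Nc3c(F)cc(-c4cccc(F)c4)cc3F)c(C)c(O)c2c1` share one core; compound 3 `CCOc1ccc2nc(C(=O)Nc3c(F)cc(-c4cccc(F)c4)cc3F)c(C)c(C(=O)O)c2c1` and compound 4 `COc1ccc2nc(C(=O)Nc3c(F)cc(-c4cccc(F)c4)cc3F)c(C)c(C(=O)O)c2c1` share another, and the difference between the two cores is not broken down here. In a functional assay on A-375 cells (Homo sapiens) for antiproliferative activity, read by MTT assay, with a stated time of 24 h, tested at 0.01 ug/mL (a higher number here means a stronger effect of the compound at the concentration tested, a lower number a weaker effect), compound 1 gives 0.1%, compound 2 gives -0.35% and compound 3 gives 0.3%; all three numbers sit within the scatter of one another, so nothing separates them at this concentration.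

One measured step matches the change to compound 4 in kind. Between compound 2 and compound 1 the change is hydrogen in place of methyl on a saturated chain carbon bound to an aromatic carbon, and it gives a number 0.5 percentage points higher from compound 2 to compound 1 (within the scatter). The change to compound 4 is hydrogen in place of methyl on a saturated chain carbon bound to an oxygen on an aromatic ring. The two changes are the same kind of change, not the same: in the first the place is on a saturated chain carbon bound to an aromatic carbon, in the second on a saturated chain carbon bound to an oxygen on an aromatic ring.

Compound 4 has not been measured in this assay. Among the compounds with values here, the step from compound 3 to compound 4 is expected to be small, about a number 0.1 percentage points lower from compound 3 to compound 4 (within the scatter), because the one comparable step, a number 0.5 percentage points higher from compound 2 to compound 1 (within the scatter), lay within the scatter and because compound 3 itself gives only 0.3%. Compound 4 is therefore expected to give about 0.2% in this assay, with the estimate spanning -1.5% to 2%.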

Compound 4, a percentage reported as inhibition, at one concentration (the size of the read-out at that concentration, not a potency): 0.05%
Beside the measured number, compound 4's estimate is 0.2 percentage points above it; the range from low to high includes it.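

In this assay the new step reads a number 0.3 percentage points lower from compound 3 to compound 4 (within the scatter), and like the earlier step it lies within the scatter. Set beside that earlier step, the replacement of methyl by hydrogen gives no difference between the two cores that can be told apart: the same change on two cores in this assay, a number 0.5 percentage points higher (within the scatter) from compound 2 to compound 1 and a number 0.3 percentage points lower (within the scatter) from compound 3 to compound 4, 0.7 percentage points apart, within the scatter of two such steps. This shows that the change leaves no readable mark on either core at this one concentration, but it does not show that the effect of the change carries from one core to the other: steps that stay within the scatter give no size to carry, and the two places differ, one on a saturated chain carbon bound to an aromatic carbon, the other on a saturated chain carbon bound to an oxygen on an aromatic ring.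

The compounds shown leave open how the same change behaves on these cores when the read-out stands clear of the scatter, as it might in a full concentration series. They also leave open what a longer chain or an amine would give in place of the ethoxy or methoxy group on the core of compound 3.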